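The source may report more compounds than this note shows. Statements on the series, on what has been measured and on what is new or still open speak of the compounds shown alone.

Compound 1, `O=c1[nH]cc(S(=O)(=O)Nc2cccc(-c3cn(-c4ccc(F)cc4)nn3)c2)c(=O)[nH]1`, in a functional assay on A549 cells (Homo sapiens) for antiproliferative activity, read by MTT assay, with a stated time of 24 h (a higher number here means a weaker inhibitor, a lower number a stronger inhibitor), sits at the limit > 20000 nM, which is a limit of the assay and not a number.
Compound 2, `O=c1[nH]cc(S(=O)(=O)Nc2cccc(-c3cn(-c4ccccc4Cl)nn3)c2)c(=O)[nH]1`, gives 2730 nM in this assay.
Compound 3, `O=c1[nH]cc(S(=O)(=O)Nc2ccc(-c3cn(-c4ccc(F)cc4)nn3)cc2)c(=O)[nH]1`, gives 9720 nM in this assay.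

Compound 1 and compound 2 share one core and differ in a single place: 2-chlorophenyl in place of 4-fluorophenyl on an aromatic nitrogen. This change brought an at least 7.3-fold lower number from compound 1 to compound 2 (0.86 log units; beyond the scatter). The step can only be given as a least size because compound 1 sits at the limit of > 20000 nM in this assay, at which 1 of the 3 values shown sits.

Compound 3 is built from the same atoms as compound 1, joined differently; the difference between the two cores is not broken down here. Compound 3 gives a number in this assay, and compound 2 gives a lower one.

Compound 4, `O=c1[nH]cc(S(=O)(=O)Nc2ccc(-c3cn(-c4ccccc4Cl)nn3)cc2)c(=O)[nH]1`, has not yet been measured. It stands to compound 3 as compound 2 stands to compound 1: 2-chlorophenyl in place of 4-fluorophenyl on an aromatic nitrogen. The place of the change is described in the same words in both pairs, so this is the same change. A step of about a 3.9-fold lower number from compound 3 to compound 4 (0.59 log units; beyond the scatter) is expected from compound 3 to compound 4, resting on the step of an at least 7.3-fold lower number from compound 1 to compound 2 (0.86 log units; beyond the scatter) seen once before. On that basis compound 4 is estimated at 2500 nM, likely between 800 nM and 8000 nM.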

Compound 4, half-maximal inhibitory concentration: 2810 nM
Estimate against measurement, compound 4: 1.1-fold (0.05 log units) below; the measured number falls inside the stated range.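

Replacing 4-fluorophenyl with 2-chlorophenyl on an aromatic nitrogen gives, in this assay, a 3.5-fold lower number from compound 3 to compound 4 (0.54 log units; beyond the scatter). Set beside the earlier step, the change points the same way on both cores, but the two sizes cannot be compared: the same change on two cores in this assay, an at least 7.3-fold lower number (0.86 log units; beyond the scatter) from compound 1 to compound 2 and a 3.5-fold lower number (0.54 log units; beyond the scatter) from compound 3 to compound 4; the limit leaves it open whether they differ. The earlier step has only a least size, so the pair shows the direction carrying over once, and it gives neither a fixed size for the change nor a rule for other cores: the limit of > 20000 nM in this assay, at which 1 of the 4 values shown sits.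

From the compounds shown here alone, only these two groups appear on that aromatic nitrogen, so it remains open whether the chlorine itself or its place on the phenyl ring goes with the lower number, a question that 2-fluorophenyl and 4-chlorophenyl could help to separate. Going by these compounds, it is also open how an unsubstituted phenyl or a phenyl carrying a carboxylic acid would read in this assay.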